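A few compounds are considered here, and "the series" means these few. Any claim that something is new, unique, unknown or untested is made for them only; others in the source may bear on it.

Measured in a functional assay on HL-60 cells (Homo sapiens) for antiproliferative activity, read by MTT assay, with a stated time of 48 h; on this read-out higher numbers stand for weaker inhibition and lower numbers for stronger inhibition:
- compound 1 `CN(C)CCCCn1c(N)c(-c2nc3ccccc3n2C)c2nc(C#N)c(C#N)nc21`: 740 nM
- compound 2 `CCN(CC)CCn1c(N)c(-c2nc3cc(Cl)ccc3[nH]2)c2nc(C#N)c(C#N)nc21`: > 50000 nM, a limit of the assay
- compound 3 `CCN(CC)CCCn1c(N)c(-c2nc3cc(Cl)ccc3[nH]2)c2nc(C#N)c(C#N)nc21`: 3470 nM

Of the two actual numbers, compound 3 holds the higher, and its nearest neighbour is compound 1 at 740 nM. Compound 4 `CN(C)CCCCn1c(N)c(-c2nc3cc(Cl)ccc3[nH]2)c2nc(C#N)c(C#N)nc21` differs from compound 3 as follows: (dimethylamino)methyl in place of diethylamino on a saturated chain carbon, three bonds along the chain from an aromatic nitrogen. Cut one bond further out, this reads 3-(diethylamino)propyl to 4-(dimethylamino)butyl.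

Among the compounds with values here, one measured step bears on this change: an at least 14-fold lower number from compound 2 to compound 3 (1.15 log units; beyond the scatter), a large drop on adding to the chain with the diethylamino end kept. That step swaps no end group, so it is only a partial guide. Compound 1 already carries the 4-(dimethylamino)butyl chain and reads 740 nM, although its core differs from that of compound 4. A far smaller drop than the measured one is therefore expected, and the expected change is a 3.2-fold lower number from compound 3 to compound 4 (0.50 log units; beyond the scatter). The estimate for compound 4 is 1100 nM, with an expected range of 350 nM to 3800 nM.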

Compound 4, half-maximal inhibitory concentration: 1480 nM
Beside the measured number, compound 4's estimate is 1.3-fold (0.13 log units) below it, within the range that was stated.
By their numbers in this assay, from the lowest: compounds 1 and 4 (each within the scatter of the next); then compound 3. At a limit, above all of these: compound 2.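

The change from 3-(diethylamino)propyl to 4-(dimethylamino)butyl gives a 2.3-fold lower number from compound 3 to compound 4 (0.37 log units; beyond the scatter) in this assay, so this position still responds to a change in the chain beyond the 3-(diethylamino)propyl stage. Compound 2 stands at a limit, so an at least 33-fold lower number from compound 2 to compound 4 (1.52 log units; beyond the scatter) gives a bound only: the limit of > 50000 nM in this assay, at which 1 of the 4 values shown sits. With the 4-(dimethylamino)butyl chain kept, 5-chloro-1H-benzimidazol-2-yl in place of 1-methyl-1H-benzimidazol-2-yl gives a 2.0-fold higher number from compound 1 to compound 4 (0.30 log units; within the scatter), so these two cannot be told apart.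

Chain length and end group change together in the step to compound 4, and the compounds shown do not separate their shares; a 4-(diethylamino)butyl or 3-(dimethylamino)propyl chain would do so. From the compounds shown here alone, it also stays open how a longer chain, or a pyrrolidine or morpholine at the chain end, would read.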